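The compounds below may be only part of what the source reports. "The series", "measured", "known", "first", "only" and "open" are said of these compounds alone.

Two compounds here share one core and differ only in the aryl group attached to the amide-type nitrogen of the ring. Compound 1 `COc1ccccc1N1C(=O)/C(=C/c2ccc(OCC(=O)Nc3ccc(C(=O)O)cc3)cc2)SC1=S` carries a 2-methoxyphenyl there, and in an assay on isolated protein for inhibition of Apoptosis regulator Bcl-2 (Homo sapiens), read by fluorescence polarization (a lower number here means a stronger inhibitor, a higher number a weaker inhibitor), compound 1 gives 10000 nM. Compound 2 `O=C(COc1ccc(/C=C2\SC(=S)N(c3ccc([N+](=O)[O-])cc3)C2=O)cc1)Nc1ccc(C(=O)O)cc1` carries a 4-nitrophenyl in its place. In this assay compound 2 reaches only > 10000 nM, which is a limit of the measurement rather than a number. The step of a number no lower from compound 1 to compound 2 (the limit leaves the size open) therefore cannot be sized; it rests on (the limit of > 10000 nM in this assay, at which 1 of the 2 values shown sits). Compound 2 thus stands at the weak edge of what can be read.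

Compound 3 `Cc1cccc(N2C(=O)/C(=C/c3ccc(OCC(=O)Nc4ccc(C(=O)O)cc4)cc3)SC2=S)c1` has not yet been measured. It differs from compound 2 in one place: 3-methylphenyl in place of 4-nitrophenyl on an amide-type nitrogen in a ring. Among the measured compounds shown here, the only measured step, a number no lower from compound 1 to compound 2 (the limit leaves the size open), exchanges one substituted phenyl for another on the same nitrogen and shows no gain, and it gives no reading for a methyl group. Compound 1, with its 2-methoxyphenyl, gives 10000 nM and is the nearest anchor. Compound 3 is therefore expected to land near that same weak level, a step of a number no higher from compound 2 to compound 3 (the limit leaves the size open) that may again end at the limit. The estimate for compound 3 is 10000 nM, with a range from 4000 nM to 30000 nM.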

Compound 3, inhibition constant: > 10000 nM
Compound 3 ended at the assay's limit; the forecaster's own chance of this, stated with the estimate: 50%; the middle value lies on the limit itself.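

In this assay compound 3 gives > 10000 nM, which is a limit of the assay and not a number. The data show a number no lower from compound 1 to compound 3 (the limit leaves the size open). At this amide-type nitrogen, then, the carbon-only 3-methylphenyl joins the 4-nitrophenyl, which carries nitrogen and oxygen, in giving no value that can be read, so these two compounds show no readable response to that change of group. The step from compound 2 to compound 3 cannot be read, and the measurements reach no further than this limit: the limit of > 10000 nM in this assay, at which 2 of the 3 values shown sit.

As far as these compounds go, how far compound 2 and compound 3 lie beyond the limit stays open, so they cannot be ranked against each other or sized against compound 1. Also open, from the compounds shown here alone, is whether a phenyl ring carrying an amine or a carboxylic acid, or a longer alkyl chain in place of the phenyl ring on this nitrogen, would give a value that can be read in this assay.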